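Swapping the phenyl substituent on the triazole of compound 1

The source may hold more compounds than are shown below. What is called first, only, known or untested is meant among the compounds shown, and "the series" means these compounds.

Compound 1 `CC1(C)[C@H]2CC[C@]1(C)N(Cc1cn(-c3ccc(F)cc3)nn1)C(=O)C2` gives 500 nM in a functional assay on SGC-7901 cells (Homo sapiens) for inhibition, read by MTT assay, with a stated time of 24 h (on this read-out higher numbers stand for weaker inhibition and lower numbers for stronger inhibition), the highest of the two numbers measured. Compound 2 `CC1(C)[C@H]2CC[C@]1(C)N(Cc1cn(-c3cccc(Br)c3)nn1)C(=O)C2` gives 120 nM, and the step of a 4.2-fold lower number from compound 1 to compound 2 (0.62 log units; beyond the scatter) came with a 3-bromophenyl in place of the 4-fluorophenyl. Compound 3 `Cc1cccc(-n2cc(CN3C(=O)C[C@@H]4CC[C@@]3(C)C4(C)C)nn2)c1` is not yet measured; its change is 3-methylphenyl in place of 4-fluorophenyl on an aromatic nitrogen. Going by the values given here, only that one step bears on it, so a modest drop is expected, a 2.3-fold lower number from compound 1 to compound 3 (0.36 log units; beyond the scatter). Compound 3 is therefore estimated at 220 nM, within a range from 100 nM to 500 nM.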

Compound 3, half-maximal inhibitory concentration: 410 nM
The estimate for compound 3 lay 1.9-fold (0.27 log units) below the measured number; measured number inside the range.
By their numbers in this assay, from the lowest: compound 2; then compounds 3 and 1 (each within the scatter of the next).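

In this assay, a step of a 1.2-fold lower number from compound 1 to compound 3 (0.09 log units; within the scatter) means that 3-methylphenyl and 4-fluorophenyl on the aromatic nitrogen cannot be told apart. Methyl in place of bromo on the same phenyl ring gives a 3.4-fold higher number from compound 2 to compound 3 (0.53 log units; beyond the scatter), so among these compounds the lower number of compound 2 goes with the bromo, and a group in that ring place is not enough on its own. No evidence here explains this difference. On these data alone, whether 3-chlorophenyl, 3-aminophenyl or 4-bromophenyl would give numbers like compound 2 or like compound 3 remains open.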